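The source may report more compounds than this note shows. Statements on the series, on what has been measured and on what is new or still open speak of the compounds shown alone.

Measured in a physicochemical assay for lipophilicity, at pH 7.4; on this read-out higher numbers stand for higher lipophilicity and lower numbers for lower lipophilicity:
compound 1 `Clc1ccc(NC2=NCCC3(CCCCC3)S2)cc1` — 1.34
compound 2 `FC(F)(F)c1ccc(NC2=NCCC3(CCCCC3)S2)cc1` — 1.31
compound 3 `CC(=O)c1cccc(NC2=NCCC3(CCCCC3)S2)c1` — 1.31

Compound 2 stands level with compound 3 at the digits shown, the two together the lowest of the three numbers, and compound 1 is set apart from compound 2 only by a number 0.03 log units lower from compound 1 to compound 2 (within the scatter), a step within the scatter. The three values are in practice one cluster.

The next compound is compound 4 `CC(C)c1ccc(NC2=NCCC3(CCCCC3)S2)cc1`. Change from compound 2: isopropyl in place of trifluoromethyl on an aromatic carbon.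

Among the compounds with values here, no measured step involves an isopropyl group. Within the data shown here, the single measured step, a number 0.03 log units lower from compound 1 to compound 2 (within the scatter), was within the scatter and bears only loosely on this change. A modest rise in this assay is expected, though poorly anchored.

Compound 4 is estimated at 1.65, between 1.2 and 2.1. That corresponds to an expected step of a number 0.34 log units higher from compound 2 to compound 4 (beyond the scatter).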

Compound 4, distribution coefficient: 1.45
The estimate for compound 4 lay 0.20 log units above the measured number; the range from low to high includes it.
By their numbers in this assay, from the lowest: compounds 2, 3, 1 and 4 (each within the scatter of the next).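

In this assay isopropyl at this aromatic carbon, para to a large group, gives a number 0.14 log units higher from compound 2 to compound 4 (within the scatter) and a number 0.11 log units higher from compound 1 to compound 4 (within the scatter) and so stays within the scatter of both trifluoromethyl and chloro. Across these three groups, the all-carbon isopropyl included, swaps at this place do not separate the compounds on this read-out. Nothing available accounts for these small steps.

From the compounds shown here alone, whether an amine, a carboxylic acid or a longer chain at this place would leave the cluster remains open. So does whether changes elsewhere on the shared core would move the number further.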